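Working notes: HeLa cytotoxicity across compounds 1 to 3

The source may hold more compounds than are shown below. What is called first, only, known or untested is meant among the compounds shown, and "the series" means these compounds.

The series is followed in an ADME assay on HeLa cells (Homo sapiens) for cytotoxicity, read by MTT assay, with a stated time of 96 h; on this read-out higher numbers stand for weaker inhibition and lower numbers for stronger inhibition. Compound 1 `COc1ccc(CN2CCN(c3ccc(C4CC(c5ccc([N+](=O)[O-])o5)=NO4)cc3)CC2)cn1` returns > 50000 nM, which is a limit of the assay and not a number. Compound 2 `O=[N+]([O-])c1ccc(C2=NOC(c3ccc(-c4cccnc4)cc3)C2)o1` returns > 50000 nM, again a limit rather than a measured number. Where compound 2 stands is thus only a boundary: both values shown sit at the limit of this assay (the limit of > 50000 nM in this assay, at which 2 of the 2 values shown sit), and no step between measured compounds exists from which the size of any change could be judged.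

Compound 3 `O=[N+]([O-])c1ccc(C2=NOC(c3ccc(-c4ccncc4)cc3)C2)o1` is not yet measured. Relative to compound 2 the change is pyridin-4-yl in place of pyridin-3-yl on an aromatic carbon; the two have the same atoms, joined differently. Among the measured compounds shown here, with no measured step to lean on, the expectation in this assay is no step beyond the usual scatter, in neither direction, and a further result at the limit is the likeliest outcome.

For compound 3 the estimate is 60000 nM, with a range from 20000 nM to 200000 nM, which amounts to an expected step that the limit leaves unreadable from compound 2 to compound 3.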

Compound 3, half-maximal inhibitory concentration: > 50000 nM
Compound 3: no number, only a limit (the forecaster's own chance of this, stated with the estimate: 85%); the middle value lies beyond the limit too.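

Compound 3 returns > 50000 nM, which is a limit and not a number, so no step from compound 2 to compound 3 can be read: the limit of > 50000 nM in this assay, at which 3 of the 3 values shown sit.

The compounds shown leave open whether pyridin-4-yl and pyridin-3-yl differ at all in this assay, and what real values compound 1, compound 2 and compound 3 would have there.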